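This account rests on a few compounds, and the source may have more. Where it says the series, first, only, none or still open, it means among the compounds named here.

Measured in a functional assay on HT-29 cells (Homo sapiens) for cytotoxicity, read by sulforhodamine B assay, with a stated time of 48 h; on this read-out lower numbers stand for stronger inhibition and higher numbers for weaker inhibition:

compound 1 `CCNC(=O)Nc1cccc(S(=O)(=O)Oc2ccccc2CC)c1`: 33000 nM
compound 2 `CCCc1ccccc1OS(=O)(=O)c1cccc(NC(=O)NCC)c1`: 25000 nM
compound 3 `CCNC(=O)Nc1cccc(S(=O)(=O)Nc2ccccc2C)c1`: 102000 nM

Compound 3 gives the highest number of the three, and its gaps to compound 1 and compound 2 both lie beyond the usual scatter. Compound 4 `CCNC(=O)Nc1cccc(S(=O)(=O)Nc2ccccc2CC)c1` has not yet been measured. It differs from compound 3 by methyl in place of hydrogen on a saturated chain carbon bound to an aromatic carbon. The same kind of change, (methyl in place of hydrogen on a saturated chain carbon, two bonds along the chain from an aromatic carbon), connects compound 1 and compound 2, where it gave a 1.3-fold lower number from compound 1 to compound 2 (0.12 log units; within the scatter); there, though, the place was two bonds along the chain from an aromatic carbon, whereas here it is bound to an aromatic carbon. The difference between the core of compound 1 and the core of compound 3 is not broken down here. Because the earlier step of a 1.3-fold lower number from compound 1 to compound 2 (0.12 log units; within the scatter) stayed within the scatter, a similarly small step is expected for compound 4, a 1.2-fold lower number from compound 3 to compound 4 (0.08 log units; within the scatter). In this assay compound 4 is estimated at 85000 nM, likely between 40000 nM and 180000 nM.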

Compound 4, half-maximal inhibitory concentration: 15000 nM
Beside the measured number, compound 4's estimate is 5.7-fold (0.75 log units) above it, outside the stated range (below it).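

In this assay, methyl in place of hydrogen on a saturated chain carbon bound to an aromatic carbon gives a 6.8-fold lower number from compound 3 to compound 4 (0.83 log units; beyond the scatter). In this series, the size of the step does not carry over from one core to the other: the same change on two cores in this assay, a 1.3-fold lower number (0.12 log units; within the scatter) from compound 1 to compound 2 and a 6.8-fold lower number (0.83 log units; beyond the scatter) from compound 3 to compound 4, 5.2-fold (0.71 log units) apart, beyond the scatter of two such steps. The two steps also differ in place, this one on the chain carbon bound to an aromatic carbon and the earlier one two bonds along the chain, so the data do not show whether the core or the place sets the size of the step.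

The compounds shown leave open how a longer chain such as butyl would behave on either core. They also leave open what an amine or a carboxylic acid at the end of the chain would do.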